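Swapping 4-Chlorophenyl for Thiophen-2-yl on a Shared Core

A few compounds are considered here, and "the series" means these few. Any claim that something is new, unique, unknown or untested is made for them only; others in the source may bear on it.

Measured compounds:
- compound 1, `Cc1ccc(C(CC/N=C(\N)NCCCc2c[nH]cn2)c2ccccn2)cc1`: 148 nM
- compound 2, `COc1ccc(C(CC/N=C(\N)NCCCc2c[nH]cn2)c2ccccn2)cc1`: 269 nM
- compound 3, `N=C(NCCCc1c[nH]cn1)NCCC(c1ccc(Cl)cc1)c1ccccn1`: 77.6 nM

All three compounds were tested in a functional assay on ileum for antagonist activity at histamine H1 receptor (Cavia porcellus); on this read-out higher numbers stand for weaker binding and lower numbers for tighter binding. Compound 1 and compound 2 differ only in methoxy in place of methyl on an aromatic carbon, and that step, a 1.8-fold higher number from compound 1 to compound 2 (0.26 log units; within the scatter), lies within the scatter. Compound 3 stands below compound 2 by a gap beyond the scatter, while its gap to compound 1 is within the scatter, so the three compounds sit close together on this read-out.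

Compound 4, `N=C(NCCCc1c[nH]cn1)NCCC(c1ccccn1)c1cccs1`, has not yet been measured. It differs from compound 3 by thiophen-2-yl in place of 4-chlorophenyl on a saturated chain carbon bound to an aromatic carbon and a saturated chain carbon. Going by the values given here, no measured step touches this exact change; the only measured step, from compound 1 to compound 2, concerns a different group on the same aromatic ring and is within the scatter. The shared core has so far tolerated changes at this position without a gap beyond the scatter between neighbouring compounds.

Given that, the value of compound 4 in this assay is expected to lie near the cluster of the three measured compounds, with a 1.9-fold higher number from compound 3 to compound 4 (0.29 log units; within the scatter) as the estimated step, and is estimated at 150 nM with a range from 50 nM to 450 nM.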

Compound 4, dissociation constant: 45.7 nM
The estimate for compound 4 lay 3.3-fold (0.52 log units) above the measured number; the measured number lies below the stated range.
By their numbers in this assay, from the lowest: compounds 4, 3, 1 and 2 (each within the scatter of the next, the first and the last beyond it).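

In this assay, thiophen-2-yl in place of 4-chlorophenyl on a saturated chain carbon bound to an aromatic carbon and a saturated chain carbon gives a 1.7-fold lower number from compound 3 to compound 4 (0.23 log units; within the scatter) and thus stays within the scatter, so at this position a five-membered aromatic ring with 1 hetero atom can stand where a six-membered aromatic ring of carbon only stood without moving the read-out beyond the scatter. The earlier step, a 1.8-fold higher number from compound 1 to compound 2 (0.26 log units; within the scatter) on this read-out, only exchanged one group for another on an aromatic carbon and left the ring in place, whereas here the ring itself is exchanged, and a group with 1 hydrogen-bond acceptor replaces one with 0 hydrogen-bond acceptors. No measurement bears on why the read-out stays within the scatter across this exchange.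

As far as these compounds go, whether a saturated ring such as cyclohexyl would be tolerated at this position in the same way, or a thiophen-2-yl ring carrying an amine or a carboxylic acid, remains open. From the compounds shown here alone, all four compounds are read in this single assay, so how thiophen-2-yl behaves at any other receptor also stays unknown.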